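Swapping 2-methoxyethyl for ethoxy on a shared core

The source may hold more compounds than are shown below. What is called first, only, known or untested is meant among the compounds shown, and "the series" means these compounds.

In an in vitro ADME assay on microsomes from liver (Homo sapiens) for metabolic stability (a lower number here means slower removal, a higher number faster removal of the compound), compound 1 (`COCCc1nc2nc(C)cc(Nc3ccc(S(F)(F)(F)(F)F)cc3)n2n1`) gives 11.5 mL.min-1.g-1, compound 2 (`CCc1nc2nc(C)cc(Nc3ccc(Cl)cc3)n2n1`) gives 12.8 mL.min-1.g-1 and compound 3 (`COCCc1nc2nc(C)cc(Nc3ccc(C(F)(F)F)cc3)n2n1`) gives 9 mL.min-1.g-1. Compound 1 therefore stands with the other two, and these three values lie within the scatter of each other. Compound 4 (`CCOc1nc2nc(C)cc(Nc3ccc(S(F)(F)(F)(F)F)cc3)n2n1`) has not yet been measured. It differs from compound 1 by ethoxy in place of 2-methoxyethyl on an aromatic carbon, between two ring nitrogen atoms.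

The measurements offer little direct guidance on this change. Among the measured compounds shown here, the one measured step, a 1.3-fold lower number from compound 1 to compound 3 (0.11 log units; within the scatter), lies within the scatter, but it concerns a different place in the molecule. For the measured compounds named here, compound 2 differs from compound 1 in more than one place, so it supplies no clean step. Going by the values given here, no measured pair isolates the swap of 2-methoxyethyl for ethoxy. The small spread of the three values in this assay gives no reason to expect a large shift, so no step beyond the scatter is expected. The estimated change is a 1.0-fold lower number from compound 1 to compound 4 (0.02 log units; within the scatter). For compound 4 the expected value is 11 mL.min-1.g-1, with an estimated range from 6 mL.min-1.g-1 to 20 mL.min-1.g-1.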

Compound 4, intrinsic clearance in microsomes: < 5 mL.min-1.g-1
Compound 4: only a limit was reported (the forecaster's own chance of this, stated with the estimate: 3%); middle value at least 2.2-fold (0.34 log units) away from the limit.
By their numbers in this assay, from the lowest: compounds 3, 1 and 2 (each within the scatter of the next). At a limit, below all of these: compound 4.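

Ethoxy in place of 2-methoxyethyl, on an aromatic carbon between two ring nitrogen atoms, gives an at least 2.3-fold lower number from compound 1 to compound 4 (0.36 log units; beyond the scatter) in this assay, so this position can register a step beyond the scatter, which the earlier compounds did not show: the only step available before, a 1.3-fold lower number from compound 1 to compound 3 (0.11 log units; within the scatter), concerned a different place in the molecule. Compound 4 gives < 5 mL.min-1.g-1, which is a limit and not a number, so the step has a known minimum but no known full size: the limit of < 5 mL.min-1.g-1 in this assay, at which 1 of the 4 values shown sits. Ethoxy and 2-methoxyethyl match in their hydrogen-bond donors and acceptors, and neither has a ring or a net charge, so this step arises with no change in those counts.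

On these data alone, the swap rests on a single pair, so it remains open whether it would carry the same weight on the trifluoromethyl compound 3 or on another group at that end of the molecule. Also open, as far as these compounds go, is how this assay would respond to an amine, a carboxylic acid or a longer ether chain at this position.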